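This account rests on a few compounds, and the source may have more. Where it says the series, first, only, none or still open, it means among the compounds named here.

Working notes on the series, read in a functional assay on L1210 cells (Mus musculus) for cytotoxicity, read by MTT assay, with a stated time of 24 h; a lower number here means a stronger inhibitor, a higher number a weaker inhibitor. Compound 1 (`COc1cc(C(=O)/C=C/c2ccc3ccccc3c2)ccc1O`) gives 54000 nM, compound 2 (`COc1cc(C(=O)/C=C/c2ccc3ccccc3c2)cc(OC)c1OC`) gives 26000 nM, and compound 3 (`COc1cc(C(=O)/C=C/c2ccc(Cl)c(Cl)c2)cc(OC)c1OC`) gives 44000 nM. Compound 3 lies within the scatter of both compound 1 and compound 2. For the measured compounds named here, no two measured compounds differ in one place, so the series offers no direct step to lean on.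

The next entry is compound 4 (`COc1cc(C(=O)/C=C/c2ccc(Cl)cc2)cc(OC)c1OC`), which goes from 3,4-dichlorophenyl to 4-chlorophenyl: hydrogen in place of chloro on an aromatic carbon. This puts hydrogen in place of chloro on an aromatic carbon, ortho to a chloro group.

No step beyond the scatter is expected in this assay, in either direction. Going by the values given here, compound 3, at 44000 nM, is the only measured compound carrying a chloro group, so the expectation stays close to it. The expected change is a 1.1-fold lower number from compound 3 to compound 4 (0.04 log units; within the scatter), which would stay within the scatter. For compound 4 the estimated value is 40000 nM, with an expected range of 16000 nM to 90000 nM.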

Compound 4, half-maximal inhibitory concentration: 44500 nM
The estimate for compound 4 lay 1.1-fold (0.05 log units) below the measured number; low and high end bracket the measured number.
By their numbers in this assay, from the lowest: compounds 2, 3, 4 and 1 (each within the scatter of the next, the first and the last beyond it).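

In this assay, for the compounds shown here, the first comparison that differs in one place gives a 1.0-fold higher number from compound 3 to compound 4 (0.00 log units; within the scatter). Compound 3 and compound 4 therefore cannot be told apart, so with the shared core and the remaining chloro group held fixed, the read-out does not distinguish chloro from hydrogen on this aromatic carbon, ortho to a chloro group. No measurement is available that would explain this result.

On these data alone, it remains open whether an amine or a carboxylic acid on this same aromatic carbon would read beyond the scatter from compound 3. As far as these compounds go, it is also open whether replacing the remaining chloro group of the 4-chlorophenyl ring with hydrogen would leave the number within the scatter of compound 4.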